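This account rests on a few compounds, and the source may have more. Where it says the series, first, only, none or still open, it means among the compounds named here.

Compound 1 `CC(C)=CCc1cc(C(=O)Nc2cc3ccc(OCC4CCN(C)C4)c(C)c3oc2=O)ccc1O`: 920 nM
Compound 2 `CC(C)=CCc1cc(C(=O)Nc2cc3ccc(OCCCNC(C)C)c(C)c3oc2=O)ccc1O`: 750 nM
Compound 3 `CC(C)=CCc1cc(C(=O)Nc2cc3ccc(OCCCN(C)C4CCCCC4)c(C)c3oc2=O)ccc1O`: 970 nM

All three compounds were tested in a functional assay on SK-BR-3 cells (Homo sapiens) for antiproliferative activity; a higher number here means a weaker inhibitor, a lower number a stronger inhibitor. Among these numbers compound 1 stands second highest of the three, with a 1.1-fold higher number from compound 1 to compound 3 (0.02 log units; within the scatter) as its nearest neighbour and a 1.2-fold lower number from compound 1 to compound 2 (0.09 log units; within the scatter) as its furthest, so every gap between these measured compounds lies within the scatter.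

Compound 4 `CC(C)=CCc1cc(C(=O)Nc2cc3ccc(OCCCNC(C)(C)c4ccccc4)c(C)c3oc2=O)ccc1O` is not yet measured. Its difference from compound 1 is 2-((1-methyl-1-phenylethyl)amino)ethyl in place of 1-methylpyrrolidin-3-yl on a saturated chain carbon bound to an oxygen on an aromatic ring. The measured steps that bear on this change are those in which the same group on compound 1 was exchanged for another amine-bearing chain: a 1.2-fold lower number from compound 1 to compound 2 (0.09 log units; within the scatter) and a 1.1-fold higher number from compound 1 to compound 3 (0.02 log units; within the scatter), and between those two products a 1.3-fold higher number from compound 2 to compound 3 (0.11 log units; within the scatter). Each of these changes to the same part of the molecule left the number within the scatter, so the expected step in this assay from compound 1 to compound 4 is none beyond the scatter, that is a 1.0-fold lower number from compound 1 to compound 4 (0.01 log units; within the scatter). Compound 4 is therefore estimated at 900 nM, with a range from 450 nM to 1800 nM.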

Compound 4, half-maximal inhibitory concentration: 960 nM
For compound 4 the middle estimate is 1.1-fold (0.03 log units) below the measured one; measured number inside the range.
By their numbers in this assay, from the lowest: compounds 2, 1, 4 and 3 (each within the scatter of the next).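

In this assay, replacing 1-methylpyrrolidin-3-yl with 2-((1-methyl-1-phenylethyl)amino)ethyl gives a step that stays within the scatter (a 1.0-fold higher number from compound 1 to compound 4 (0.02 log units; within the scatter)), so this position also tolerates a group carrying a six-membered aromatic ring of carbon only. The same holds against the two open-chain amines (a 1.0-fold lower number from compound 3 to compound 4 (0.00 log units; within the scatter); a 1.3-fold higher number from compound 2 to compound 4 (0.11 log units; within the scatter)), and the second of these steps is phenyl in place of hydrogen on a saturated chain carbon bound to an amine nitrogen and two saturated chain carbons. Nothing available explains why the number stays this level across these changes.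

Every compound shown carries an amine on this chain, so it remains open whether a carboxylic acid or a plain alkyl chain in its place would shift the number. Also open, from the compounds shown here alone, is what a longer chain would do.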